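The source may report more compounds than this note shows. Statements on the series, on what has been measured and on what is new or still open speak of the compounds shown alone.

In a functional assay on U-937 cells (Homo sapiens) for cytotoxicity, read by MTT assay, with a stated time of 48 h (a higher number here means a weaker inhibitor, a lower number a stronger inhibitor), compound 1 `S=C(Nc1ccc(Cl)cc1)Nc1nc2ccccc2s1` reaches only a limit, > 50000 nM. Among the compounds with values here, compound 2 `Cc1ccc2nc(Nc3nc4ccccc4s3)sc2c1` gives 48400 nM in this assay, the only plain number among the two values shown. The other value sits at a limit, (the limit of > 50000 nM in this assay, at which 1 of the 2 values shown sits). Compound 3 `Clc1ccc2nc(Nc3nc4ccccc4s3)sc2c1` differs from compound 2 by chloro in place of methyl on an aromatic carbon. Within the data shown here, no measured pair shows this change, so the expected step in this assay is small, no larger than the usual scatter, in no particular direction. The step of a 1.1-fold lower number from compound 2 to compound 3 (0.03 log units; within the scatter) that this estimate means is expected to stay within that scatter. Compound 3 is thus expected to give about 45000 nM in this assay, between 20000 nM and 100000 nM, with a fair chance that only a limit is reported.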

Compound 3, half-maximal inhibitory concentration: > 50000 nM
Compound 3 gave a limit, no number; the forecaster's own chance of this, stated with the estimate: 50%; middle value at least 1.1-fold (0.04 log units) away from the limit.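

In this assay, putting chloro in place of methyl on this aromatic carbon gives an at least 1.0-fold higher number from compound 2 to compound 3 (0.01 log units; that floor lies within the scatter). Compound 3 gives a limit, not a number, so this step is only a floor and the true size of the change cannot be read. Compound 3 also adds one more compound to those reported only as a limit: the limit of > 50000 nM in this assay, at which 2 of the 3 values shown sit.

What the compounds shown leave open is whether an amine, a carboxylic acid or a longer chain on this aromatic carbon would move the number clearly beyond the scatter. On these data alone, whether any group here could give a much lower number also remains unknown.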